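Bromo for methyl on the indole ring in two cores

The source may hold more compounds than are shown below. What is called first, only, known or untested is meant among the compounds shown, and "the series" means these compounds.

Compound 1 `COC(=O)[C@@]1(C)CCC=C2[C@@H]1CC[C@@H](C)[C@]2(C)Cc1c[nH]c2c(C)cccc12` and compound 2 `COC(=O)[C@@]1(C)CCC=C2[C@@H]1CC[C@@H](C)[C@]2(C)Cc1c[nH]c2c(Br)cccc12` share one core; compound 3 `COC(=O)[C@@]1(C)CC[C@@H]2C3=C1CC[C@@H](C)[C@]3(C)Cc1c2[nH]c2ccc(C)cc12` and compound 4 `COC(=O)[C@@]1(C)CC[C@@H]2C3=C1CC[C@@H](C)[C@]3(C)Cc1c2[nH]c2ccc(Br)cc12` share another. How the two cores differ is not broken down here. In a functional assay on SW1573 cells (Homo sapiens) for inhibition, read by sulforhodamine B assay, with a stated time of 48 h (a lower number here means a stronger inhibitor of growth, a higher number a weaker inhibitor of growth), compound 1 gives 7800 nM and compound 2 gives 14000 nM; the change between them is bromo in place of methyl on an aromatic carbon and made a step of a 1.8-fold higher number from compound 1 to compound 2 (0.25 log units; within the scatter). In this assay compound 3 gives 15000 nM, a number that sits within the scatter of compound 1 and compound 2. The change from compound 3 to compound 4 is bromo in place of methyl on an aromatic carbon, the same kind of change as from compound 1 to compound 2, but not the same: in the first core the place is part of a fused or bridged system of two rings, ortho to a fused ring and meta to a fused ring, whereas in the second it is part of a fused or bridged system of five rings, meta to a fused ring and para to a fused ring. Going by the values given here, a step like the earlier one is expected from compound 3 to compound 4, a 1.6-fold higher number from compound 3 to compound 4 (0.20 log units; within the scatter), because the only precedent is a 1.8-fold higher number from compound 1 to compound 2 (0.25 log units; within the scatter). In this assay compound 4 is therefore estimated at 24000 nM, between 9000 nM and 60000 nM.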

Compound 4, concentration for 50% growth inhibition: 12000 nM
Compound 4: the middle estimate sits 2.0-fold (0.30 log units) above what was measured; low and high end bracket the measured number.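

In this assay, bromo in place of methyl on an aromatic carbon of the second core gives a 1.3-fold lower number from compound 3 to compound 4 (0.10 log units; within the scatter), a step too small to read as an effect. Set beside the step on the first core, it does not separate from it: the same change on two cores in this assay, a 1.8-fold higher number (0.25 log units; within the scatter) from compound 1 to compound 2 and a 1.3-fold lower number (0.10 log units; within the scatter) from compound 3 to compound 4, 2.2-fold (0.35 log units) apart, within the scatter of two such steps. This shows that in both pairs the change leaves growth inhibition within the scatter, so nothing here marks the two cores as responding differently; it does not show that the change carries over with a fixed size or direction, as each core supplies a single pair, the place on the ring differs between the cores, and steps this small could hide a modest real effect.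

Groups other than methyl and bromo remain open at these places, for example an amine, a carboxylic acid or a longer chain. Also open, as far as these compounds go, is how each core would respond if the change were made at the place used on the other core.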